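The compounds below may be only part of what the source reports. "The series", "measured", "known", "first", "only" and "open" are said of these compounds alone.

Two compounds of this series carry numbers in an assay on CHO cells for antagonist activity at transient receptor potential cation channel subfamily V member 1 (Homo sapiens), read by FLIPR; on this read-out higher numbers stand for weaker inhibition and lower numbers for stronger inhibition. Compound 1 `CC(C(=O)NCc1ccc(C(F)(F)F)cc1N1CCC(Cc2ccccc2)CC1)c1ccc(NS(C)(=O)=O)c(F)c1` gives 1.4 nM. Compound 2 `CC(C(=O)NCc1ccc(C(F)(F)F)cc1N1CCN(C2CCCCC2)CC1)c1ccc(NS(C)(=O)=O)c(F)c1` gives 13.8 nM, the higher of the two numbers, with compound 1 at a lower number by a gap beyond the scatter. Compound 3 `CC(C(=O)NCc1ccc(C(F)(F)F)cc1[N+](=O)[O-])c1ccc(NS(C)(=O)=O)c(F)c1` is not yet measured; it differs from compound 2 by nitro in place of 4-cyclohexylpiperazin-1-yl on an aromatic carbon. Within the data shown here, no measured pair shows a change of this kind, so the size of the step rests on judgment. The expected step in this assay is an 18-fold higher number from compound 2 to compound 3 (1.26 log units; beyond the scatter), toward a higher number and beyond the scatter. Compound 3 is estimated at 250 nM, within 40 nM to 2500 nM.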

Compound 3, inhibition constant: "not active" (no number reported)
No number was reported for compound 3; the estimate stays without a comparison.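

Among these compounds, compound 3 is reported as not active in this assay without a number, and no step from compound 2 to compound 3 can be read. The compounds shown leave open how far nitro in place of 4-cyclohexylpiperazin-1-yl moves the number, and no measurement here bears on a cause.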